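An Ester in Place of an Amide at the Carbonyl Carbon

The source may hold more compounds than are shown below. What is called first, only, known or untested is meant among the compounds shown, and "the series" means these compounds.

Compound 2 `CCn1c(C(=O)Nc2ccc(OC(F)(F)F)cc2)ccc1C(CC)(CC)c1ccc(OCC(=O)C(C)(C)C)c(C)c1` and compound 1 `CCOC(=O)CC(C)OC(=O)c1ccc(C(CC)(CC)c2ccc(OCC(=O)C(C)(C)C)c(C)c2)n1CC` share a core and differ only at one carbonyl carbon. In an assay on HL-60 cells for agonist activity at vitamin D3 receptor (Homo sapiens), read by microscopy, with a stated time of 96 h (a higher number here means that more compound is needed for the effect, a lower number that less compound is needed), compound 1 gives > 50000 nM, which is a limit of the assay and not a number. In this assay compound 2 also gives > 50000 nM, again a limit. The step that the two limits leave unreadable from compound 1 to compound 2 therefore cannot be read, since the limit of > 50000 nM in this assay, at which 2 of the 2 values shown sit, shows that both values sit at the same limit.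

Compound 3 `CCOC(=O)c1ccc(OC(=O)c2ccc(C(CC)(CC)c3ccc(OCC(=O)C(C)(C)C)c(C)c3)n2CC)cc1` has not yet been measured. It differs from compound 2 in one place: 4-(ethoxycarbonyl)phenoxy in place of (4-(trifluoromethoxy)phenyl)amino on a carbonyl carbon. Going by the values given here, the only measured step that bears on this change is the one from compound 1 to compound 2, and its size is not readable, so no direction or magnitude can be taken from it. Given that both measured compounds sit at the limit described by the limit of > 50000 nM in this assay, at which 2 of the 2 values shown sit, the expectation for compound 3 is that it too remains at or near that limit, with no step beyond the scatter, a number no higher from compound 2 to compound 3 (the limit leaves the size open). Compound 3 is accordingly estimated at 50000 nM in this assay, within 10000 nM to 200000 nM, with a high chance that only a limit is reported.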

Compound 3, half-maximal effective concentration: 45600 nM
Estimate against measurement, compound 3: 1.1-fold (0.04 log units) above; measured number inside the range.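

In this assay, going by these compounds alone, compound 3 gives 45600 nM, the only value of the three that is a number, and the exchange at the carbonyl carbon comes out as an at least 1.0-fold lower number from compound 2 to compound 3 (0.04 log units; that floor lies within the scatter). The other exchange, on the oxygen next to a carbonyl group, gives an at least 1.0-fold lower number from compound 1 to compound 3 (0.04 log units; that floor lies within the scatter), while the step from compound 1 to compound 2 cannot be read. These floors show that a 4-(ethoxycarbonyl)phenoxy group at this position can yield a readable number, but they establish no difference beyond the scatter, and the other two compounds remain at a limit of the assay and not a number: the limit of > 50000 nM in this assay, at which 2 of the 3 values shown sit.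

Compound 3 differs from compound 2 in both the atom attached to the carbonyl carbon and the substituent on the aromatic ring, so the compounds shown do not separate the contribution of the ester oxygen from that of the ethoxycarbonyl group. Going by these compounds, it also remains open how a carboxylic acid in place of the ethoxycarbonyl group, or an amine on the aromatic ring, would read in this assay.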